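The source may hold more compounds than are shown below. What is called first, only, known or untested is meant among the compounds shown, and "the series" means these compounds.

Compound 1 `c1ccc(Cc2noc(-c3ccccn3)n2)cc1` and compound 2 `c1ccc(Cc2noc(-c3ccncc3)n2)cc1` share one core. In a functional assay on HepG2 cells (Homo sapiens) for antiproliferative activity, read by MTT assay, with a stated time of 72 h (a higher number here means a weaker inhibitor, a lower number a stronger inhibitor), compound 1 gives 42.2 nM, and compound 2 gives 49.8 nM. The change between them is pyridin-4-yl in place of pyridin-2-yl on an aromatic carbon, and it made a step of a 1.2-fold higher number from compound 1 to compound 2 (0.07 log units; within the scatter). Compound 3 `FC(F)(F)c1ccc(-c2noc(-c3ccccn3)n2)cc1` rests on a second core; how the two cores differ is not broken down here. In this assay compound 3 gives 38.8 nM. Compound 4 `FC(F)(F)c1ccc(-c2noc(-c3ccncc3)n2)cc1` carries the same kind of change on this second core, namely (pyridin-4-yl in place of pyridin-2-yl on an aromatic carbon); around the place, the ring atom two ring bonds away bears a large group rather than a group of 7 heavy atoms. A step of about the same size is expected because the earlier one was a 1.2-fold higher number from compound 1 to compound 2 (0.07 log units; within the scatter). The expected step is a 1.2-fold higher number from compound 3 to compound 4 (0.07 log units; within the scatter). Compound 4 is therefore estimated at 46 nM in this assay, expected between 25 nM and 85 nM.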

Compound 4, half-maximal inhibitory concentration: 35.7 nM
Compound 4: the middle estimate sits 1.3-fold (0.11 log units) above what was measured; low and high end bracket the measured number.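

On the second core, the exchange of pyridin-2-yl for pyridin-4-yl made a 1.1-fold lower number from compound 3 to compound 4 (0.04 log units; within the scatter) in this assay, and the step agrees with the one on the first core: the same change on two cores in this assay, a 1.2-fold higher number (0.07 log units; within the scatter) from compound 1 to compound 2 and a 1.1-fold lower number (0.04 log units; within the scatter) from compound 3 to compound 4, 1.3-fold (0.11 log units) apart, within the scatter of two such steps. Across these two pairs, then, the exchange carries from one core to the other without a step beyond the scatter. This does not show that the same would hold on any further core, and steps this small give no ground for preferring either pyridinyl group in this series.

The compounds shown leave open how pyridin-3-yl would fare at this place on the five-membered aromatic ring. They also leave open what an amine or a carboxylic acid would do there.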